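The source may report more compounds than this note shows. Statements on the series, on what has been measured and on what is new or still open speak of the compounds shown alone.

Measured compounds, with values from a functional assay on A549 cells (Homo sapiens) for antiproliferative activity, read by MTT assay, with a stated time of 72 h, in the presence of a further agent that is not named here; a lower number here means a stronger inhibitor, a higher number a weaker inhibitor

- compound 1 `Nc1nc2[nH]c(CCSCC(=O)N[C@@H](CCC(=O)O)C(=O)O)cc2c(=O)[nH]1` gives 668 nM
- compound 2 `Nc1nc2[nH]c(CCSCCC(=O)NCc3ccncc3)cc2c(=O)[nH]1` gives 7870 nM
- compound 3 `Nc1nc2[nH]c(CCSCCC(=O)NCc3cccnc3)cc2c(=O)[nH]1` gives 1070 nM

Compound 1 stands level, within the scatter, with compound 3, and the number of compound 2 is clearly higher than both.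

The open question is compound 4 `Nc1nc2[nH]c(CCSCC(=O)NCc3ccccn3)cc2c(=O)[nH]1`, which carries (pyridin-2-yl)methyl in place of 1,3-dicarboxypropyl on an amide-type nitrogen.

Within the data shown here, one measured step bears on this, and only indirectly. Pyridin-3-yl in place of pyridin-4-yl gives a modest change beyond the scatter (a 7.4-fold lower number from compound 2 to compound 3 (0.87 log units; beyond the scatter)). The position of attachment on the pyridine ring therefore matters in this small set. No pyridin-2-yl partner has been measured, however, and the chain leading to the amide in compound 4 differs from that in compound 2 and compound 3. Among the measured compounds shown here, no measured step isolates the loss of 1,3-dicarboxypropyl either.

The pyridine amides measured so far do not fall clearly below compound 1, so a moderate rise in this assay is expected, no larger than the measured pyridine step and with wide uncertainty.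

The estimated change is upward (a 3.0-fold higher number from compound 1 to compound 4 (0.48 log units; beyond the scatter)).

Compound 4 is expected at 2000 nM (estimated range 500 nM to 8000 nM).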

Compound 4, half-maximal inhibitory concentration: 14100 nM
Beside the measured number, compound 4's estimate is 7.1-fold (0.85 log units) below it; measured number above the stated range.
By their numbers in this assay, from the lowest: compounds 1 and 3 (each within the scatter of the next); then compounds 2 and 4 (each within the scatter of the next).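

In this assay, among these compounds, (pyridin-2-yl)methyl in place of 1,3-dicarboxypropyl on the amide-type nitrogen is a large step, a 21-fold higher number from compound 1 to compound 4 (1.32 log units; beyond the scatter), and it is the only measured change at this place with the rest of the structure held constant. The substituent on this nitrogen therefore has a strong bearing on the read-out, and in this pair the open-chain group with its two carboxyl groups gives the lower number. The step exchanges several features at once, including the defined stereocentre, the hydrogen-bond donors and the absence of a ring, and no information on which of these matters is available.

Still open, going by these compounds, is whether a single carboxylic acid on the same amide nitrogen, or a simple benzyl group, would stay near compound 1 or near compound 4. Compound 2 and compound 3 carry a longer chain before the amide, so how the pyridin-2-yl, pyridin-3-yl and pyridin-4-yl attachments rank on one common chain also remains unsettled.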